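The source may hold more compounds than are shown below. What is called first, only, known or untested is meant among the compounds shown, and "the series" means these compounds.

Working notes on the series, read in an assay on a protein complex for inhibition of NEDD8 activating enzyme (Homo sapiens), read by HTRF, with a stated time of 2 h, in the presence of a further agent that is not named here; on this read-out higher numbers stand for weaker inhibition and lower numbers for stronger inhibition. Compound 1 `NS(=O)(=O)OC[C@@H]1C[C@@H](n2nnc3c(N[C@H]4CCc5ccccc54)ncnc32)C[C@@H]1O` gives 0.21 nM. Compound 2 `NS(=O)(=O)OC[C@@H]1C[C@@H](n2nnc3c(NCCCc4ccccc4)ncnc32)C[C@@H]1O` gives 149 nM, and compound 3 `COC(=O)[C@H]1C=C[C@@H](Nc2ncnc3c2nnn3[C@@H]2C[C@@H](COS(N)(=O)=O)[C@@H](O)C2)C1` gives 80.9 nM. Among these three numbers compound 3 stands second highest: a 1.8-fold lower number from compound 2 to compound 3 (0.27 log units; within the scatter) leaves it at the same level as compound 2, while a 390-fold higher number from compound 1 to compound 3 (2.59 log units; beyond the scatter) places it far from compound 1.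

The step to compound 4 `NS(=O)(=O)OC[C@@H]1C[C@@H](n2nnc3c(Nn4ccc5ccccc54)ncnc32)C[C@@H]1O` is a group of 9 heavy atoms (8 carbon, 1 nitrogen; one five-membered aromatic ring with 1 hetero atom, one six-membered aromatic ring of carbon only) in place of a group of 9 heavy atoms (7 carbon, 2 oxygen; one five-membered non-aromatic ring of carbon only), on a nitrogen on an aromatic ring. The measured steps that bear on it are the two into compound 3. a 390-fold higher number from compound 1 to compound 3 (2.59 log units; beyond the scatter) shows that the group with one five-membered non-aromatic ring of carbon only and one six-membered aromatic ring of carbon only gave a far lower number than the ester-bearing group, whereas a 1.8-fold lower number from compound 2 to compound 3 (0.27 log units; within the scatter) shows the 3-phenylpropyl group of compound 2 at about the level of the ester-bearing group. The group entering in compound 4 again brings one five-membered ring and one six-membered aromatic ring, here both aromatic, the five-membered one with 1 hetero atom. Going by the values given here, no measured compound carries 1H-indol-1-yl, so a large but only partial recovery of the gap to compound 1 is expected. Compound 4 is estimated at 5 nM, with a range from 0.5 nM to 50 nM. This amounts to an expected step of a 16-fold lower number from compound 3 to compound 4 (1.21 log units; beyond the scatter).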

Compound 4, half-maximal inhibitory concentration: > 10000 nM
Compound 4 gave a limit, no number; the forecaster's own chance of this, stated with the estimate: 5%; middle value at least 2000-fold (3.30 log units) from the limit.
By their numbers in this assay, from the lowest: compound 1; then compounds 3 and 2 (each within the scatter of the next). At a limit, above all of these: compound 4.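

Compound 4 reads as a limit of the assay and not as a number: the limit of > 10000 nM in this assay, at which 1 of the 4 values shown sits. With 1H-indol-1-yl on a nitrogen on an aromatic ring, the steps are an at least 120-fold higher number from compound 3 to compound 4 (2.09 log units; beyond the scatter), an at least 67-fold higher number from compound 2 to compound 4 (1.82 log units; beyond the scatter) and an at least 47000-fold higher number from compound 1 to compound 4 (4.67 log units; beyond the scatter), all beyond the scatter. The earlier compounds shown here left open whether a five-membered ring paired with a six-membered aromatic ring was enough for a low number, and compound 4 carries such a pair yet stands apart from compound 1, so the pair alone is not enough.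

The compounds shown do not separate the contribution of the hetero atom in the five-membered ring from that of its aromatic character. On these data alone, how 1H-indol-3-yl or benzyl would read on this nitrogen also remains open.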